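The source may report more compounds than this note shows. Statements on the series, on what has been measured and on what is new or still open speak of the compounds shown alone.

Measured so far in a functional assay for inhibition, with Oryctolagus cuniculus as the target; a higher number here means a weaker inhibitor, a lower number a stronger inhibitor:

compound 1 `CC(=O)/C=C/c1cccc(C)c1O` — 3630 nM
compound 2 `COc1ccc(/C=C/C(C)=O)c(O)c1` — 35500 nM
compound 3 `CC(=O)/C=C/c1cc(C)ccc1O` — 8000 nM

Compound 3 gives the second highest of the three numbers. Its nearest neighbour is compound 1, whose number is lower by a margin beyond the scatter; the furthest is compound 2, whose number is higher, again beyond the scatter. No pair among these three differs in a single place, so no measured step is available to lean on.

Compound 4 `CC(=O)/C=C/c1cc(O)ccc1O` is not yet measured. Relative to compound 3 the change is hydroxy in place of methyl on an aromatic carbon. The methyl that leaves is the same group that sets compound 1 and compound 3 apart from compound 2 only in position, and compound 2, which carries an oxygen-bearing group on the ring where the others carry methyl, gives the highest number of the three. That is the only indication the set offers about exchanging methyl for an oxygen group, and it rests on a different position.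

Expectation: a modest move to a higher number in this assay, possibly no more than the scatter; a small step is expected from compound 3 to compound 4, a 1.5-fold higher number from compound 3 to compound 4 (0.18 log units; within the scatter). Compound 4 is therefore estimated at 12000 nM, with a range from 3500 nM to 40000 nM.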

Compound 4, half-maximal inhibitory concentration: 1430 nM
Compound 4: middle estimate off by 8.4-fold (0.92 log units), on the high side; the whole stated range lies above it.
By their numbers in this assay, from the lowest: compound 4; then compound 1; then compound 3; then compound 2.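

In this assay, hydroxy in place of methyl on the aromatic carbon para to a hydroxy group and meta to a group of 5 heavy atoms gives a 5.6-fold lower number from compound 3 to compound 4 (0.75 log units; beyond the scatter) and this step lies beyond the scatter. It is the first comparison in the series that differs in one place only, so this position is now shown to be sensitive to the exchange, with the number moving in the lower direction: the heavy-atom count stays the same, while one hydrogen-bond donor and one hydrogen-bond acceptor enter with the hydroxy. No measurement at hand gives a reason for this step.

A single exchange cannot show whether an amine, a fluorine or a carboxylic acid on the same carbon would follow hydroxy, follow methyl or do neither. Also open, from the compounds shown here alone, is how the number responds at the other positions of the ring, and whether a longer chain in place of the group of 5 heavy atoms would leave this step intact.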